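The compounds below may be only part of what the source reports. "The series", "measured", "known", "first", "only" and "open" are said of these compounds alone.

Of the compounds shown here, three on the shared core have been read so far in a functional assay on the whole organism (brain) with Mus musculus as the target; on this read-out lower numbers stand for an effect already at smaller amounts and higher numbers for an effect only at larger amounts of compound. Among the compounds with values here, compound 1 `N#Cc1cccc(OCCc2c[nH]cn2)c1` gives 2.9 mg/kg, the only actual number. Compound 3 `Clc1cc(Cl)cc(OCCc2c[nH]cn2)c1` has only a limit, > 10 mg/kg. Compound 2 `COC(=O)c1ccc(OCCc2c[nH]cn2)cc1` also has only a limit, > 3 mg/kg. Its true position relative to the other two compounds cannot be read from these values.

The next compound to be read is compound 4 `CCc1ccc(OCCc2c[nH]cn2)cc1`, which carries ethyl in place of methoxycarbonyl on an aromatic carbon of a six-membered aromatic ring of carbon only, para to a group of 8 heavy atoms: ethyl in place of methoxycarbonyl on an aromatic carbon. Within the data shown here, no two measured compounds differ in one place only, so no measured step gauges this change. Among the measured compounds shown here, the expectation rests on compound 1 at 2.9 mg/kg, the one number available on the shared core. A small step is expected, with no direction foreseen beyond the scatter, and the estimate is a step that the limit leaves unreadable from compound 2 to compound 4. A reading reported only as a limit remains possible, as it was for compound 2 and compound 3. In this assay the expected value for compound 4 is 5 mg/kg, with an estimated range from 1.5 mg/kg to 15 mg/kg.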

Compound 4, dose for half-maximal effect: > 10 mg/kg
Compound 4 was reported as a limit; the forecaster's own chance of this, stated with the estimate: 35%; middle value at least 2.0-fold (0.30 log units) away from the limit.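

In this assay compound 2 gives > 3 mg/kg, which is a limit. Compound 4 gives > 10 mg/kg, also a limit. No step can be read between compound 2 and compound 4. The compounds shown leave open whether ethyl in place of methoxycarbonyl on the aromatic carbon changes the dose for half-maximal effect at all.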